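This account rests on a few compounds, and the source may have more. Where it says the series, first, only, none or still open, it means among the compounds named here.

Compound 1 `O=C(C1CC1)N1CCc2nc(C#Cc3ccccc3)sc2C1`; in an assay on HEK293 cells for positive allosteric modulation of metabotropic glutamate receptor 5 (Homo sapiens), read by FLIPR, with a stated time of 1 h (on this read-out higher numbers stand for an effect only at larger amounts of compound and lower numbers for an effect already at smaller amounts), compound 1 reaches only the assay limit > 10000 nM.
Compound 2 `O=C(C1CCCO1)N1CCc2nc(C#Cc3ccccc3)sc2C1`; in this assay compound 2 gives 790 nM.

For the measured compounds named here, compound 2 holds the only numerical value shown, the other result being a limit (the limit of > 10000 nM in this assay, at which 1 of the 2 values shown sits). Going by the values given here, the one measured step, an at least 12-fold lower number from compound 1 to compound 2 (1.10 log units; beyond the scatter), was large. Compound 3 `CC1CCCC(C(=O)N2CCc3nc(C#Cc4ccccc4)sc3C2)C1` carries 3-methylcyclohexyl in place of oxolan-2-yl on a carbonyl carbon. That change moves away from the oxolan-2-yl ring through a different route than the measured step, which swapped cyclopropyl for oxolan-2-yl, so the measured step bears on it only loosely. Compound 3 is expected to show a 1.9-fold higher number from compound 2 to compound 3 (0.28 log units; within the scatter). Compound 3 is therefore estimated at 1500 nM, within 200 nM to 10000 nM.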

Compound 3, half-maximal effective concentration: 100 nM
For compound 3 the middle estimate is 15-fold (1.18 log units) above the measured one; measured number outside the range, below it.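

At this position, on a carbonyl carbon, a ring of carbon only serves better than the oxolan-2-yl ring, with a 7.9-fold lower number from compound 2 to compound 3 (0.90 log units; beyond the scatter) in this assay. The hydrogen-bond acceptor of the oxolan-2-yl group is therefore not required for activity here, as 3-methylcyclohexyl has none. Measured against cyclopropyl, the change gives an at least 100-fold lower number from compound 1 to compound 3 (2.00 log units; beyond the scatter), and this step rests on a limit for compound 1: the limit of > 10000 nM in this assay, at which 1 of the 3 values shown sits.

Open, as far as these compounds go, is whether the methyl group contributes to this gain, as plain cyclohexyl would show. Also open, from the compounds shown here alone, is how a ring bearing an amine or a carboxylic acid would read in this assay.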